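The compounds below may be only part of what the source reports. "The series", "measured", "known", "first", "only" and "open" are said of these compounds alone.

Compound 1, `CC(=O)OC[C@H]1O[C@@H](n2cnc3c(N)ncnc32)[C@H](O)[C@@H]1O`: in an assay on COS-7 cells for inhibition of sodium/nucleoside cotransporter 2 (Homo sapiens), read by scintillation counting, in the presence of a further agent that is not named here (a higher number here means a weaker inhibitor, a lower number a stronger inhibitor), compound 1 gives > 100000 nM, which is a limit of the assay.
Compound 2, `CCOC(=O)OC[C@H]1O[C@@H](n2cnc3c(N)ncnc32)[C@H](O)[C@@H]1O`: in this assay compound 2 gives > 100000 nM, again a limit.
Compound 3, `CCCCCC(=O)OC[C@H]1O[C@@H](n2cnc3c(N)ncnc32)[C@H](O)[C@@H]1O`: in this assay compound 3 gives > 100000 nM, also a limit.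

Compound 3 therefore stands nowhere on a numerical scale; it sits with the other two at the limit of > 100000 nM in this assay, at which 3 of the 3 values shown sit. The measured steps are accordingly unreadable: a step that the two limits leave unreadable from compound 1 to compound 2, a step that the two limits leave unreadable from compound 1 to compound 3 and a step that the two limits leave unreadable from compound 2 to compound 3. None of them tells whether changing the group on the carbonyl carbon moves inhibition at all.

The unmeasured compound 4, `CCNC(=O)OC[C@H]1O[C@@H](n2cnc3c(N)ncnc32)[C@H](O)[C@@H]1O`, differs from compound 3 by ethylamino in place of pentyl on a carbonyl carbon. Within the data shown here, all three steps bearing on the carbonyl substituent are unreadable, so no step of any size or direction can be forecast in this assay beyond the scatter. Compound 4 is expected to remain at the limit, with an expected step that the limit leaves unreadable from compound 3 to compound 4, because all comparable values sit at the limit of > 100000 nM in this assay, at which 3 of the 3 values shown sit. Compound 4 is thus estimated at 150000 nM, between 30000 nM and 1000000 nM.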

Compound 4, half-maximal inhibitory concentration: > 100000 nM
Compound 4 ended at the assay's limit; the forecaster's own chance of this, stated with the estimate: 85%; the middle value does not contradict the limit.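

In this assay, among these compounds, compound 4 gives > 100000 nM, which is a limit, so no step from compound 1, compound 2 or compound 3 to compound 4 can be read: the limit of > 100000 nM in this assay, at which 4 of the 4 values shown sit. The compounds shown leave open whether any group on this carbonyl carbon changes inhibition at all.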